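The compounds below may be only part of what the source reports. "The series", "measured", "known", "first", "only" and "open" are said of these compounds alone.

The three measured compounds share one core. Compound 1 `Cc1ccccc1NNC(=O)c1ccc(NS(=O)(=O)c2cnc(O)nc2O)cc1` is tested in a functional assay on SGC-7901 cells (Homo sapiens) for antiproliferative activity, read by MTT assay, with a stated time of 24 h; a higher number here means a weaker inhibitor, a lower number a stronger inhibitor. In this assay compound 1 gives > 20000 nM, which is a limit of the assay and not a number. Compound 3 `O=C(NNc1ccccc1Cl)c1ccccc1NS(=O)(=O)c1cnc(O)nc1O` likewise reaches only a limit in this assay, where compound 3 gives > 20000 nM. Going by the values given here, compound 2 `O=C(NNc1cccc(Cl)c1)c1cccc(NS(=O)(=O)c2cnc(O)nc2O)c1` is the one compound with a measured number: in this assay compound 2 gives 11800 nM. Compound 1 thus stands at the limit of > 20000 nM in this assay, at which 2 of the 3 values shown sit, and its standing among the three cannot be fixed more closely than that. Compound 4 `O=C(NNC(=O)c1ccccc1Cl)c1ccc(NS(=O)(=O)c2cnc(O)nc2O)cc1` differs from compound 1 in one place: (2-chlorophenyl)carbonyl in place of 2-methylphenyl on an amine nitrogen. Among the compounds with values here, no measured pair isolates this change, so nothing in the data sets its size or direction. Compound 2 shows that a numbered value close to the limit is possible on this core. Compound 4 is expected to remain weak, with the step estimated at an at least 1.1-fold lower number from compound 1 to compound 4 (0.04 log units; that floor lies within the scatter), and a limit rather than a number remains likely. The estimate for compound 4 is 18000 nM, within a range of 7000 nM to 45000 nM.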

Compound 4, half-maximal inhibitory concentration: 3240 nM
The estimate for compound 4 lay 5.6-fold (0.74 log units) above the measured number; the measured number lies below the stated range.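

In this assay, replacing 2-methylphenyl with (2-chlorophenyl)carbonyl on the amine nitrogen gives an at least 6.1-fold lower number from compound 1 to compound 4 (0.79 log units; beyond the scatter). Going by these compounds alone, the earlier compounds held no pair that isolated any change, so this is the first sign that this position on the core of compound 1 can respond to substitution, and the step lies beyond the scatter. Its true size stays unfixed, since it is only a floor set by the limit of compound 1: the limit of > 20000 nM in this assay, at which 2 of the 4 values shown sit.

The compounds shown leave open whether the step belongs to the added carbonyl, to the chlorine in place of the methyl, or to both, as compound 4 carries the two together. A (2-methylphenyl)carbonyl group or an unsubstituted benzoyl group on the same nitrogen would separate these contributions.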